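This account rests on a few compounds, and the source may have more. Where it says the series, first, only, none or still open, it means among the compounds named here.

Working notes on the series. Compound 3 `COc1ccc(-n2nc(C(=O)Nc3ccc(Oc4ccnc5cc(OCCCN6CCCCC6)c(OC)cc45)c(F)c3)c(C)cc2=O)cc1` sits between the other two measured members in a functional assay on U-87MG ATCC cells (Homo sapiens) for inhibition, read by MTT assay, with a stated time of 72 h; on this read-out lower numbers stand for stronger inhibition and higher numbers for weaker inhibition: compound 3 gives 1800 nM, compound 1 `COc1cc2c(Oc3ccc(NC(=O)c4nn(-c5ccccc5C(F)(F)F)c(=O)cc4C)cc3F)ccnc2cc1OCCCN1CCC(C)CC1` gives 1120 nM, and compound 2 `COc1ccc(-n2nc(C(=O)Nc3ccc(Oc4ccnc5cc(OCCCN6CCCC6)c(OC)cc45)c(F)c3)c(C)cc2=O)cc1` gives 2960 nM, all three within the scatter of one another. Among the compounds with values here, the one single-point step known here, a 1.6-fold lower number from compound 2 to compound 3 (0.22 log units; within the scatter), is also within the scatter. Compound 4 `COc1ccc(-n2nc(C(=O)Nc3ccc(Oc4ccnc5cc(OCCCN6CCC(C)CC6)c(OC)cc45)c(F)c3)c(C)cc2=O)cc1` differs from compound 3 by methyl in place of hydrogen on a saturated ring carbon, on the same chain that varied between compound 2 and compound 3. Within the data shown here, compound 1 carries the same 4-methylpiperidin-1-yl group but a different aryl on the shared core, so no direct step to it is known; its value and that of compound 3 lie within the scatter. No step beyond the scatter is therefore expected for this change. Compound 4 is expected at 1500 nM, between 700 nM and 3200 nM, giving an expected 1.2-fold lower number from compound 3 to compound 4 (0.08 log units; within the scatter).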

Compound 4, half-maximal inhibitory concentration: 2840 nM
For compound 4 the middle estimate is 1.9-fold (0.28 log units) below the measured one; the range from low to high includes it.
By their numbers in this assay, from the lowest: compounds 1, 3, 4 and 2 (each within the scatter of the next, the first and the last beyond it).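

In this assay, methyl on a saturated ring carbon, three ring bonds from the ring nitrogen, gives no separation from the parent piperidin-1-yl compound (a 1.6-fold higher number from compound 3 to compound 4 (0.20 log units; within the scatter)), and 4-methylpiperidin-1-yl in place of pyrrolidin-1-yl gives none either (a 1.0-fold lower number from compound 2 to compound 4 (0.02 log units; within the scatter)). Within the data shown here, the only step beyond the scatter so far lies away from this ring, on an aromatic nitrogen, where 4-methoxyphenyl replaces 2-(trifluoromethyl)phenyl (a 2.5-fold higher number from compound 1 to compound 4 (0.40 log units; beyond the scatter)). No measurement at hand accounts for this aryl step. Open, on these data alone, is whether morpholin-4-yl or a longer chain would leave the values within the scatter. Also open, as far as these compounds go, is whether the aryl step recurs with piperidin-1-yl or pyrrolidin-1-yl on the chain.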